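The source may report more compounds than this note shows. Statements on the series, on what has been measured and on what is new or still open speak of the compounds shown alone.

Measured in an ADME assay on Huh-7 cells (Homo sapiens) for cytotoxicity, with a stated time of 72 h; on this read-out lower numbers stand for higher toxicity in this test and higher numbers for lower toxicity in this test:
compound 1 `CS(=O)(=O)Nc1ccc2c(c1)S(=O)(=O)N=C(C1=C(O)C3CCCC3N(Cc3ccc(F)cn3)C1=O)N2` — > 33000 nM
compound 2 `CC(C)(C)CCN1C(=O)C(C2=NS(=O)(=O)c3cc(NS(C)(=O)=O)ccc3N2)=C(O)C2CCCCCC21` — > 10000 nM
compound 3 `Cc1cc(CN2C(=O)C(C3=NS(=O)(=O)c4cc(NS(C)(=O)=O)ccc4N3)=C(O)[C@H]3CCC[C@H]32)ccc1F` — > 1000 nM

All three values are limits of the assay, not numbers. Compound 1 stands at the limit of > 33000 nM in this assay, at which 1 of the 3 values shown sits. Compound 2 stands at the limit of > 10000 nM in this assay, at which 1 of the 3 values shown sits. Compound 3 stands at the limit of > 1000 nM in this assay, at which 1 of the 3 values shown sits. Among the measured compounds shown here, none of the three shows a measurable cytotoxic concentration, so no step between measured compounds can be drawn, and nothing in these values separates one compound from another beyond the scatter; compound 1 simply stands at the highest of the three limits, which says only that its test ran to a higher concentration.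

Compound 4 `CS(=O)(=O)Nc1ccc2c(c1)S(=O)(=O)N=C(C1=C(O)C3CCCC3N(Cc3ccccc3)C1=O)N2` is not yet measured. It differs from compound 1 in one place: phenyl in place of 5-fluoropyridin-2-yl on a saturated chain carbon bound to an amide-type nitrogen in a ring. With every measured value a limit, the expected change in this assay is none beyond the scatter, a number no higher from compound 1 to compound 4 (the limit leaves the size open), and the result for compound 4 is itself likely to be reported only as a limit. For compound 4 the estimate in this assay is 33000 nM, with a range from 10000 nM to 100000 nM.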

Compound 4, half-maximal cytotoxic concentration: > 33000 nM
Compound 4: only a limit was reported; the forecaster's own chance of this, stated with the estimate: 80%; the middle value sits exactly at the limit.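

No step can be read from compound 1 to compound 4: in this assay both compounds are reported only as limits, not as numbers. Still open, going by these compounds, is whether phenyl and 5-fluoropyridin-2-yl differ at all in this read-out, as neither compound has a measurable cytotoxic concentration.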